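Solubility After Replacing the Isopentyl Group

A few compounds are considered here, and "the series" means these few. Any claim that something is new, unique, unknown or untested is made for them only; others in the source may bear on it.

Measured so far:
Compound 1, `Fc1ccc(Cc2ccc3c(NCCCNCc4ccco4)ccnc3c2)cc1`: 4200 nM
Compound 2, `CC(C)CCc1ccc2c(NCCCNCc3ccco3)ccnc2c1`: 4200 nM

Compound 2, `CC(C)CCc1ccc2c(NCCCNCc3ccco3)ccnc2c1`, is one of two compounds with a measurement in a physicochemical assay for solubility, with a stated time of 18 h, at pH 7.4; on this read-out higher numbers stand for higher solubility and lower numbers for lower solubility. In this assay compound 2 gives 4200 nM, and compound 1 gives 4200 nM, so compound 2 stands level with compound 1 within the scatter.

Compound 3, `COc1ccccc1Oc1ccc2c(NCCCNCc3ccco3)ccnc2c1`, differs from compound 2 in one place: 2-methoxyphenoxy in place of isopentyl on an aromatic carbon. Within the data shown here, the only measured step that speaks to such a change is no change at the digits printed from compound 1 to compound 2 (within the scatter); there, the group at a neighbouring position of the shared core was exchanged and the solubility did not move beyond the scatter. That change was different in kind from the present one, so it is a weak guide.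

For compound 3 the expected step in this assay is therefore no change at the digits printed from compound 2 to compound 3 (within the scatter), no change beyond the scatter. The estimate for compound 3 is 4200 nM, within a range from 1400 nM to 12000 nM.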

Compound 3, solubility: 14500 nM
Estimate against measurement, compound 3: 3.5-fold (0.54 log units) below; measured number outside the range, above it.
By their numbers in this assay, from the lowest: compounds 1 and 2 (each within the scatter of the next); then compound 3.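

Placing 2-methoxyphenoxy on this aromatic carbon of the shared core in place of isopentyl gives a 3.5-fold higher number from compound 2 to compound 3 (0.54 log units; beyond the scatter) in this assay, and placing it there in place of 4-fluorobenzyl gives a 3.5-fold higher number from compound 1 to compound 3 (0.54 log units; beyond the scatter). The earlier pair showed two different groups reading level, whereas this result shows that the number in this assay can differ with the group at this place. No measurement shown here accounts for the difference.

The compounds shown leave open which part of 2-methoxyphenoxy goes with the higher number: the linking oxygen, the methoxy group or the aromatic ring. They also leave open how an amine or a carboxylic acid at this place would read in this assay.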